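The source may hold more compounds than are shown below. What is called first, only, known or untested is meant among the compounds shown, and "the series" means these compounds.

Measured compounds:
Compound 1 `O=C(/C=C/c1cccc(OCc2ccccc2)c1)c1ccc(O)cc1` gives 800 nM in a functional assay on 2008 cells (Homo sapiens) for cytotoxicity, read by MTT assay, with a stated time of 68 h; a higher number here means a weaker inhibitor, a lower number a stronger inhibitor.
Compound 2 `Cc1ccc(C(=O)/C=C/c2cccc(OCc3ccccc3)c2)cc1` gives 12900 nM in this assay.

Compound 1 stands at the lowest of the two numbers. Among the measured compounds shown here, its only neighbour is compound 2, and the single step between them, a 16-fold higher number from compound 1 to compound 2 (1.21 log units; beyond the scatter), is large and well beyond the scatter: replacing the hydroxy on an aromatic carbon by methyl weakened the compound considerably.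

Compound 3 `O=C(/C=C/c1cccc(OCc2ccccc2)c1)c1cccc(Br)c1` has not yet been measured in this assay. It differs from compound 1 in one place: 3-bromophenyl in place of 4-hydroxyphenyl on a carbonyl carbon. For the measured compounds named here, the 4-hydroxyphenyl that leaves is the same group whose hydroxy was lost in the step to compound 2, so that step is the one that bears on this change; the 3-bromophenyl that enters likewise brings no hydrogen-bond donor or acceptor, and no further measured step shows what the bromine itself adds. Going by the values given here, the expectation for compound 3 is therefore a weakening on the order of a 13-fold higher number from compound 1 to compound 3 (1.10 log units; beyond the scatter), with a wide range because the entering group has no measured precedent. Compound 3 is estimated at 10000 nM, between 3000 nM and 35000 nM.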

Compound 3, half-maximal inhibitory concentration: 5700 nM
The estimate for compound 3 lay 1.8-fold (0.24 log units) above the measured number, within the range that was stated.
By their numbers in this assay, from the lowest: compound 1; then compound 3; then compound 2.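

In this assay a second replacement of the 4-hydroxyphenyl on the carbonyl carbon also gives a weaker compound, with a 7.1-fold higher number from compound 1 to compound 3 (0.85 log units; beyond the scatter), so among the compounds shown the weakening is not confined to the 4-methylphenyl and both groups without a hydrogen-bond donor stand higher than compound 1. The entering group matters as well as the leaving one, since the exchange of 4-methylphenyl for 3-bromophenyl gives a 2.3-fold lower number from compound 2 to compound 3 (0.35 log units; beyond the scatter), a modest step that still lies beyond the scatter, and the position therefore distinguishes between two replacements that both lack the hydroxy. No independent measurement is available to explain either step.

Because compound 2 and compound 3 differ both in the atom carried by the ring and in the name of the ring position, the compounds shown cannot separate the effect of bromine or methyl from that of where each sits, and a 4-bromophenyl or a 3-hydroxyphenyl would be needed to do so. From the compounds shown here alone, how an amine or a carboxylic acid on this ring would compare with the hydroxy of compound 1 also remains open.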